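Swapping a methoxyphenyl for a thienyl on a thiophene core

This account rests on a few compounds, and the source may have more. Where it says the series, first, only, none or still open, it means among the compounds named here.

Measured so far:
compound 1, `Cc1ccc(-c2sc(N)c(C(=O)c3ccc(Cl)cc3)c2CC(C)(C)C)cc1`, 1%
compound 2, `COc1ccc(-c2sc(N)c(C(=O)c3ccc(Cl)cc3)c2CC(C)(C)C)cc1`, 2%

Both compounds were tested in an assay on CHO cells for displacement of a labelled ligand from adenosine receptor A3 (Homo sapiens), read by scintillation counting, tested at 10 uM; on this read-out lower numbers stand for less inhibition and higher numbers for more inhibition at the one concentration tested (going by the name of the read-out). Within the data shown here, compound 2 gives 2%, the higher of the two numbers, with compound 1 closest to it; the only measured step, a number 1 percentage points higher from compound 1 to compound 2 (within the scatter), lies within the scatter, so the two compounds cannot be told apart on this read-out.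

Compound 3, `CC(C)(C)Cc1c(-c2ccsc2)sc(N)c1C(=O)c1ccc(Cl)cc1`, has not yet been measured. It differs from compound 2 in one place: thiophen-3-yl in place of 4-methoxyphenyl on an aromatic carbon. Among the measured compounds shown here, no measured step replaces an aryl ring by thiophen-3-yl, so nothing directly bears on this change; the one step that exists was within the scatter and both numbers sit near the bottom of the read-out. The step of a number 1 percentage points higher from compound 2 to compound 3 (within the scatter) is therefore expected to stay within the scatter. Compound 3 is estimated to give 3%, between -7% and 14%.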

Compound 3, a percentage reported as inhibition, at one concentration (the size of the read-out at that concentration, not a potency): 4%
For compound 3 the middle estimate is 1 percentage points below the measured one, within the range that was stated.
By their numbers in this assay, from the lowest: compounds 1, 2 and 3 (each within the scatter of the next).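

In this assay, putting thiophen-3-yl in place of the six-membered aromatic ring gives a number 2 percentage points higher from compound 2 to compound 3 (within the scatter) and a number 3 percentage points higher from compound 1 to compound 3 (within the scatter). This shows that the position next to the ring sulfur can carry a five-membered aromatic ring with 5 heavy atoms, as well as 4-methoxyphenyl with 8, while compounds 1, 2 and 3 remain impossible to tell apart on this read-out. Nothing available gives a reason for these numbers.

As far as these compounds go, it remains open whether any group at this position can produce a number clearly beyond the scatter, for example a carboxylic acid or a phenyl ring carrying an amine. The compounds shown also leave open what a change elsewhere would do, such as a longer chain in place of the neopentyl group.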